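Chloro in place of the benzimidazolyl sulfanyl group

The source may hold more compounds than are shown below. What is called first, only, known or untested is meant among the compounds shown, and "the series" means these compounds.

Values in a functional assay on PC-3 cells (Homo sapiens) for cytotoxicity, read by MTT assay, with a stated time of 72 h (a higher number here means a weaker inhibitor, a lower number a stronger inhibitor), so far:
- compound 1 `C=C1C2=C(C(=O)N1OC)[C@H](OC(=O)CSc1nc3ccccc3s1)[C@@](C)(O)[C@H](CCCCC)O2` gives 5000 nM
- compound 2 `C=C1C2=C(C(=O)N1OC)[C@H](OC(=O)CSc1nc3ccccc3[nH]1)[C@@](C)(O)[C@H](CCCCC)O2` gives 6400 nM
- compound 3 `C=C1C2=C(C(=O)N1OC)[C@H](OC(=O)CCl)[C@@](C)(O)[C@H](CCCCC)O2` has no value yet

Among the compounds with values here, compound 2 has only one neighbour on these numbers, and the two values lie within the scatter of each other. The next change leads to compound 3 and is larger: chloro in place of (1H-benzimidazol-2-yl)sulfanyl on a saturated chain carbon bound to a carbonyl carbon In words, this is chloro in place of (1H-benzimidazol-2-yl)sulfanyl on a saturated chain carbon bound to a carbonyl carbon.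

Within the data shown here, only one measured step bears on it, a 1.3-fold higher number from compound 1 to compound 2 (0.11 log units; within the scatter) with 1H-benzimidazol-2-yl in place of 1,3-benzothiazol-2-yl on a sulfur. That step keeps the sulfur, whereas here the sulfur and both aromatic rings leave, so it is weak guidance. Among the measured compounds shown here, no measured compound shows what chloro does. No direction is therefore favoured in this assay, and no step beyond the scatter is firmly expected, though the uncertainty is wide.

The estimated change is a 1.3-fold lower number from compound 2 to compound 3 (0.11 log units; within the scatter) and rests on little data. The expected value for compound 3 is 5000 nM with an estimated range of 1500 nM to 20000 nM for now.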

Compound 3, half-maximal inhibitory concentration: 2400 nM
Beside the measured number, compound 3's estimate is 2.1-fold (0.32 log units) above it, within the range that was stated.
By their numbers in this assay, from the lowest: compound 3; then compounds 1 and 2 (each within the scatter of the next).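

In this assay, chloro in place of (1H-benzimidazol-2-yl)sulfanyl on a saturated chain carbon bound to a carbonyl carbon gives a 2.7-fold lower number from compound 2 to compound 3 (0.43 log units; beyond the scatter), and chloro in place of (1,3-benzothiazol-2-yl)sulfanyl gives a 2.1-fold lower number from compound 1 to compound 3 (0.32 log units; beyond the scatter); both steps are modest but beyond the scatter. This place in the series therefore does not need the sulfur or either aromatic ring system to keep activity in this cell assay, and among these three compounds, the one with the single chlorine atom has the lowest number, while the two larger sulfanyl groups remain within the scatter of each other. No measurement available here accounts for the lower number of compound 3.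

The compounds shown do not tell whether the lower number belongs to chloro itself or simply follows the loss of the larger aromatic sulfanyl groups. Bromo, an amine, a carboxylic acid or a small methylsulfanyl group at the same place would help separate these two readings, and a phenylsulfanyl group would test whether the ring nitrogen atoms matter at all.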